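Adding a hydroxy group to a weakly active flavanonol

This account rests on a few compounds, and the source may have more. Where it says the series, first, only, none or still open, it means among the compounds named here.

Three compounds have been measured in a functional assay on RAW264.7 cells (Rattus norvegicus) for inhibition, with RAW264.7 (Mus musculus) as the target, read by Griess assay, with stated times of 2 h and 16 h; a higher number here means a weaker inhibitor, a lower number a stronger inhibitor:
- compound 1 `O=C1c2ccccc2O[C@@H](c2cccc(O)c2O)[C@@H]1O`, for which this assay reports only a limit, > 100000 nM;
- compound 2 `O=C1c2ccc(O)c(O)c2O[C@H](c2cccc(O)c2O)[C@H]1O`, which in this assay gives 17000 nM;
- compound 3 `O=C1c2ccc(O)cc2O[C@H](c2cccc(O)c2O)[C@H]1O`, which in this assay gives 70700 nM.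

Compound 2 differs from compound 3 by hydroxy in place of hydrogen on an aromatic carbon, and that change brings a 4.2-fold lower number from compound 3 to compound 2 (0.62 log units; beyond the scatter). Compound 4 `O=C1c2c(O)cccc2O[C@@H](c2cccc(O)c2O)[C@@H]1O` is not yet measured; it differs from compound 1 by hydroxy in place of hydrogen on an aromatic carbon. The difference between the core of compound 1 and that of compound 3 is not broken down here. The two places are not identical: in compound 2 the entering group is also ortho to a hydroxy group, in compound 4 it is not, so this is the same kind of change, not the same change. Compound 1 stands at the limit of > 100000 nM in this assay, at which 1 of the 3 values shown sits, so the starting point is a bound rather than a number. Compound 4 is therefore expected near 80000 nM, a step of an at least 1.2-fold lower number from compound 1 to compound 4 (0.09 log units; that floor lies within the scatter), resting on the modest gain seen in a 4.2-fold lower number from compound 3 to compound 2 (0.62 log units; beyond the scatter) and weakened by the uncertain start.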

Compound 4, half-maximal inhibitory concentration: > 100000 nM
Compound 4: no number, only a limit (the forecaster's own chance of this, stated with the estimate: 45%); middle value at least 1.2-fold (0.09 log units) away from the limit.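

Compound 1 and compound 4 both give only a limit in this assay, not a number, so the step between them cannot be read. Going by these compounds, whether this hydroxy group changes inhibition on the core of compound 1 stays open.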